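The compounds below may be only part of what the source reports. "The series", "measured", "known", "first", "only" and "open" are said of these compounds alone.

Measured so far:

Compound 1 `CCN1C/C(=C\c2ccc(OC)cc2)C2=NN(C(N)=S)C(c3ccc(OC)cc3)C2C1` — in a physicochemical assay for inhibition, read by colorimetric assay, tested at 1 mg/mL (a lower number here means less inhibition, a higher number more inhibition at the concentration tested (going by the name of the read-out)), compound 1 gives 88.2%
Compound 2 `COc1ccc(/C=C2\CCCc3c2nc(N)c(C#N)c3-c2ccc(OC)c(OC)c2)cc1OC` — compound 2 gives 9.73%
Compound 3 `COc1ccc(/C=C/C2=NN(C(N)=S)C(c3ccc(OC)cc3)C2)cc1` — compound 3 gives 84.5%

Of the three numbers, compound 1 has the highest, but compound 3 sits within the usual scatter of it, so the two cannot be told apart; only compound 2 lies far below both, beyond the scatter. No pair of these compounds differs in a single place, so no measured step is available to lean on.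

Compound 4 `CCN1C/C(=C\c2ccc(OC)cc2)C2=NN(c3nc(-c4ccccc4)cs3)C(c3ccc(OC)cc3)C2C1` is not yet measured. It differs from compound 1 in one place: a group of 11 heavy atoms (9 carbon, 1 nitrogen, 1 sulfur; one five-membered aromatic ring with 2 hetero atoms, one six-membered aromatic ring of carbon only) in place of a group of 3 heavy atoms (1 carbon, 1 nitrogen, 1 sulfur; no ring), on an amine nitrogen in a ring. The group that leaves carries a hydrogen-bond donor; the group that enters carries none and is much larger, with two aromatic rings.

Among the measured compounds shown here, with no measured step of this kind, the expectation rests only on the three values shown. The step of a number 28.2 percentage points lower from compound 1 to compound 4 (beyond the scatter) is expected to be a fall in inhibition beyond the scatter, though with wide uncertainty. Compound 4 is therefore estimated at 60%, within a range from 25% to 88%.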

Compound 4, a percentage reported as inhibition, at one concentration (the size of the read-out at that concentration, not a potency): 60.5%
For compound 4 the middle estimate is 0.5 percentage points below the measured one; measured number inside the range.
By their numbers in this assay, from the lowest: compound 2; then compound 4; then compounds 3 and 1 (each within the scatter of the next).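

In this assay, putting 4-phenyl-1,3-thiazol-2-yl in place of the small open-chain group on the amine nitrogen in a ring gives a number 27.7 percentage points lower from compound 1 to compound 4 (beyond the scatter). This position therefore responds to the change, yet it accepts a much larger group with two aromatic rings without losing the read-out altogether: compound 4 still gives 60.5%. The group that leaves carries a hydrogen-bond donor, while the one that enters carries none and is larger; this single step does not separate those differences, and nothing measured here accounts for the fall.

On these data alone, it remains open whether a plain 1,3-thiazol-2-yl without the phenyl, or an acetyl group, would sit closer to compound 1 or to compound 4. Whether the same exchange would have a similar effect on compound 3, which carries the same small group, is also unknown.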